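Swapping a furan for a thiophene on a shared core

This account rests on a few compounds, and the source may have more. Where it says the series, first, only, none or still open, it means among the compounds named here.

Compound 3 `CC1=C(C(=O)OC2CCCCC2)C(c2ccoc2)NC(=O)N1` gives 1% in an assay on membranes from HeLa cells for displacement of a labelled ligand from adenosine receptor A3 (Homo sapiens), read by scintillation counting, with a stated time of 180 min, tested at 1 uM (on this read-out higher numbers stand for more inhibition at the one concentration tested (going by the name of the read-out) and lower numbers for less inhibition), the lowest of the three numbers measured. Compound 2 `CCCC(=O)C1=C(C)NC(=O)NC1c1cccs1` gives 2%, within the scatter of compound 3, while compound 1 `CC1=C(C(=O)C2CC2)C(c2cccs2)NC(=O)N1` gives 15%, beyond it. Compound 4 `CC1=C(C(=O)OC2CCCCC2)C(c2cccs2)NC(=O)N1` differs from compound 3 in one place: thiophen-2-yl in place of furan-3-yl on a saturated ring carbon. Within the data shown here, the only measured step, a number 13 percentage points lower from compound 1 to compound 2 (beyond the scatter), changes a ketone chain, not the aromatic ring, so no step bears directly on this change. Both compounds carrying thiophen-2-yl sit at low inhibition, so a step of a number 4 percentage points higher from compound 3 to compound 4 (within the scatter) is expected, not beyond the scatter. Compound 4 is therefore estimated at 5%, with a range from -5% to 20%.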

Compound 4, a percentage reported as inhibition, at one concentration (the size of the read-out at that concentration, not a potency): 1%
Compound 4: the middle estimate sits 4 percentage points above what was measured; low and high end bracket the measured number.
By their numbers in this assay, from the lowest: compounds 3, 4 and 2 (each within the scatter of the next); then compound 1.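

In this assay, thiophen-2-yl in place of furan-3-yl on the saturated ring carbon gives no change at the digits printed from compound 3 to compound 4 (within the scatter) and so shows that these two rings read alike when cyclohexyloxy sits on the carbonyl carbon. Cyclohexyloxy in place of propyl gives a number 1 percentage points lower from compound 2 to compound 4 (within the scatter) while cyclohexyloxy in place of cyclopropyl gives a number 14 percentage points lower from compound 1 to compound 4 (beyond the scatter) and so compound 1 alone stands apart among these four. No measured evidence offers a reason for these results.

On these data alone, whether the two rings would also read alike on the core of compound 1 stays open. So does the effect of a phenyl ring on the saturated ring carbon.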